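Isopropoxy for methylsulfanyl: working notes

The source may hold more compounds than are shown below. What is called first, only, known or untested is meant among the compounds shown, and "the series" means these compounds.

Measured so far:
compound 1, `COc1ccc(Nc2nccc(-c3sc(SC)nc3C)n2)c(OC)c1`: 530 nM
compound 2, `COc1ccc(Nc2nccc(-c3cn(C4CCCC4)c4ccccc34)n2)c(OC)c1`: 1740 nM

In a functional assay on MV4-11 cells (Homo sapiens) for inhibition, read by resazurin assay, with a stated time of 72 h (a higher number here means a weaker inhibitor of growth, a lower number a stronger inhibitor of growth), compound 1 gives the lower of the two numbers; compound 2 gives a number that is higher by more than the scatter. Compound 3, `COc1ccc(Nc2nccc(-c3sc(OC(C)C)nc3C)n2)c(OC)c1`, has not yet been measured. It differs from compound 1 by isopropoxy in place of methylsulfanyl on an aromatic carbon. Among the compounds with values here, no measured pair shows a change of this kind, so the direction is open; a step of modest size in either direction, or none beyond the scatter, is expected. For compound 3 the estimate is 700 nM, within 250 nM to 2000 nM. The step of a 1.3-fold higher number from compound 1 to compound 3 (0.12 log units; within the scatter) is expected to stay near the scatter.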

Compound 3, concentration for 50% growth inhibition: 8690 nM
Estimate against measurement, compound 3: 12-fold (1.09 log units) below; measured number above the stated range.
By their numbers in this assay, from the lowest: compound 1; then compound 2; then compound 3.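

In this assay, within the data shown here, the position on the aromatic carbon next to the ring nitrogen and next to the ring sulfur proves sensitive to substitution: isopropoxy in place of methylsulfanyl gives a 16-fold higher number from compound 1 to compound 3 (1.21 log units; beyond the scatter), the first single-place change and one well beyond the scatter. Isopropoxy is thus a poor replacement for methylsulfanyl on the core of compound 1. No measurement available bears on the reason for this loss. Still open, from the compounds shown here alone, is whether the loss follows the change from sulfur to oxygen or the larger group. Methoxy or isopropylsulfanyl at this position would separate the two, and an amine there remains untested in the compounds shown.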